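Swapping the furan for a dienyl amide on a dodecyl serinamide

The source may hold more compounds than are shown below. What is called first, only, known or untested is meant among the compounds shown, and "the series" means these compounds.

Three amides of a threonine-derived core have been measured for cytotoxicity. In a functional assay on HepG2 cells (Homo sapiens) for cytotoxicity, read by MTT assay, with a stated time of 48 h (on this read-out lower numbers stand for stronger inhibition and higher numbers for weaker inhibition), compound 1 `CCCCCCCCCCCCCCCCCCNC(=O)[C@@H](N)[C@@H](C)O` gives 44500 nM. Compound 2 `CCCCCCCCNC(=O)[C@@H](NC(=O)c1ccccc1)[C@@H](C)O` gives 136000 nM in this assay, and compound 3 `CCCCCCCCCCCCNC(=O)[C@@H](NC(=O)c1ccco1)[C@@H](C)O` gives 147000 nM. Compound 3 thus shows the highest of the three numbers; its value and that of compound 2 lie within the scatter of each other, while compound 1 gives a number beyond the scatter below that of compound 3.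

Compound 4 `C/C=C/C=C/C(=O)N[C@H](C(=O)NCCCCCCCCCCCC)[C@@H](C)O` differs from compound 3 in one place: penta-1,3-dien-1-yl in place of furan-2-yl on a carbonyl carbon. For the measured compounds named here, no pair of measured compounds isolates this kind of change, so the direction of the step cannot be read from the data. Given that compound 2 and compound 3 differ in both acyl group and chain and still give values within the scatter, the step from compound 3 to compound 4 is expected to stay small, likely no change beyond the scatter, a 1.2-fold lower number from compound 3 to compound 4 (0.09 log units; within the scatter). Compound 4 is therefore estimated at 120000 nM in this assay, with a range from 50000 nM to 290000 nM.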

Compound 4, half-maximal inhibitory concentration: > 400000 nM
Compound 4: only a limit was reported (the forecaster's own chance of this, stated with the estimate: 15%); middle value at least 3.3-fold (0.52 log units) from the limit.
By their numbers in this assay, from the lowest: compound 1; then compounds 2 and 3 (each within the scatter of the next). At a limit, above all of these: compound 4.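

For the compounds shown here, this is the first step that isolates the acyl group, and it shows that this position is not indifferent to the change: with the rest of the molecule held constant, penta-1,3-dien-1-yl in place of furan-2-yl on a carbonyl carbon gives an at least 2.7-fold higher number from compound 3 to compound 4 (0.43 log units; beyond the scatter), although both groups have the same heavy-atom count. In this assay, compound 4 gives > 400000 nM, which is a limit and not a number. Only the minimum size of the step can therefore be read: the limit of > 400000 nM in this assay, at which 1 of the 4 values shown sits.

The compounds shown leave open whether the step follows the loss of the ring, the loss of the ring oxygen or the arrival of the two double bonds. A saturated pentyl chain or a phenyl ring on the same carbonyl carbon, with the dodecyl chain kept, would help separate these.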